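A few compounds are considered here, and "the series" means these few. Any claim that something is new, unique, unknown or untested is made for them only; others in the source may bear on it.

Measured in a functional assay on HT-1080 cells (Homo sapiens) for antiproliferative activity, read by MTT assay, with a stated time of 72 h; on this read-out lower numbers stand for stronger inhibition and higher numbers for weaker inhibition:
compound 1 `COc1ccc(-c2sc(C(=O)O)cc2-c2cc(OC)c(OC)c(OC)c2)cc1[N+](=O)[O-]`: 37200 nM
compound 2 `COc1ccc(-c2sc(C(=O)O)cc2-c2cc(OC)c(OC)c(OC)c2)cc1OCc1ccccc1`: > 100000 nM
compound 3 `COc1ccc(-c2sc(C(=O)O)cc2-c2cc(OC)c(OC)c(OC)c2)cc1O`: 7510 nM

Compound 2 stands at a limit and has no number: the limit of > 100000 nM in this assay, at which 1 of the 3 values shown sits.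

Compound 4 `COc1ccc(-c2sccc2-c2cc(OC)c(OC)c(OC)c2)cc1OCc1ccccc1`, not yet measured, departs from compound 2 by hydrogen in place of carboxy on an aromatic carbon, next to the ring sulfur.

Among the compounds with values here, no measured step touches this place. The three available steps, an at least 2.6-fold higher number from compound 1 to compound 2 (0.42 log units; beyond the scatter), a 5.0-fold lower number from compound 1 to compound 3 (0.69 log units; beyond the scatter) and an at least 13-fold lower number from compound 2 to compound 3 (1.12 log units; beyond the scatter), all change another group, while the carboxy stays. They show only how wide steps run in this series, so the size expected here is loosely set. Since compound 2 sits at a limit, a readable result for compound 4 can lie only on the lower side. A lower number is therefore expected, of a size comparable with an at least 13-fold lower number from compound 2 to compound 3 (1.12 log units; beyond the scatter), though with wide uncertainty.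

The expected change is an at least 10-fold lower number from compound 2 to compound 4 (1.00 log units; beyond the scatter).

The estimate for compound 4 is 10000 nM, with an expected range from 800 nM to 100000 nM.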

Compound 4, half-maximal inhibitory concentration: > 100000 nM
Compound 4 ended at the assay's limit (the forecaster's own chance of this, stated with the estimate: 20%); at least 10-fold (1.00 log units) between middle value and limit.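

No step can be read between compound 2 and compound 4, since both stand at a limit in this assay: the limit of > 100000 nM in this assay, at which 2 of the 4 values shown sit.
The compounds shown leave open what hydrogen in place of carboxy does in a compound with a readable value, such as compound 3 at 7510 nM.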